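Swapping the aryl group on the hydrazone arm: compound 3

The compounds below may be only part of what the source reports. "The series", "measured", "known", "first", "only" and "open" are said of these compounds alone.

Measured so far:
- Compound 1, `COc1ccccc1-c1nnc(-c2ccc(C(=O)N/N=C/c3cc(O)ccc3O)cc2)o1`, gives 100000 nM in an ADME assay on THP-1 cells (Homo sapiens) for cytotoxicity; a higher number here means a weaker inhibitor, a lower number a stronger inhibitor.
- Compound 2, `COc1ccccc1-c1nnc(-c2ccc(C(=O)N/N=C/c3ccc([N+](=O)[O-])cc3)cc2)o1`, gives 203000 nM in this assay.

Compound 2 holds the highest of the two numbers; its nearest neighbour is compound 1, reached through a 2.0-fold higher number from compound 1 to compound 2 (0.31 log units; beyond the scatter). Compound 3, `COc1ccccc1-c1nnc(-c2ccc(C(=O)N/N=C/c3cccc(O)c3)cc2)o1`, differs from compound 2 in a single place: 3-hydroxyphenyl in place of 4-nitrophenyl on a carbon with a double bond to nitrogen. For the measured compounds named here, the one measured step that bears on this is the change from compound 1 to compound 2, where a hydroxyl-bearing phenyl gave way to the 4-nitrophenyl and the number rose by a 2.0-fold higher number from compound 1 to compound 2 (0.31 log units; beyond the scatter). The change to compound 3 runs the other way, reintroducing a hydroxyl-bearing phenyl, though with one hydroxyl rather than two and in a different position. The number in this assay is therefore expected to fall back toward that of compound 1, by a modest amount. Compound 3 is estimated at 130000 nM, with a range from 60000 nM to 300000 nM, which corresponds to an expected step of a 1.6-fold lower number from compound 2 to compound 3 (0.19 log units; within the scatter).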

Compound 3, half-maximal inhibitory concentration: 398000 nM
Compound 3: the middle estimate sits 3.1-fold (0.49 log units) below what was measured, and the stated range ends below it.
By their numbers in this assay, from the lowest: compound 1; then compounds 2 and 3 (each within the scatter of the next).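

In this assay, the 3-hydroxyphenyl group on the carbon with a double bond to nitrogen cannot be told apart from 4-nitrophenyl (a 2.0-fold higher number from compound 2 to compound 3 (0.29 log units; within the scatter)), so a single hydroxy on this ring does not bring the number back to that of compound 1. For the compounds shown here, the more telling comparison is with compound 1 itself: hydrogen in place of hydroxy on an aromatic carbon gives a clear change (a 4.0-fold higher number from compound 1 to compound 3 (0.60 log units; beyond the scatter)), which makes the hydroxy missing from compound 3 the one single-place change here that separates a hydroxy-bearing pair. Among these three compounds, compound 1 with its 2,5-dihydroxyphenyl group is the only one set apart from both others, with the lower number and so the stronger effect on the cells.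

Why that second hydroxy counts is not explained by anything available here.
On these data alone, it also remains open whether an amine or a carboxylic acid in place of that hydroxy would keep the number near that of compound 1, or whether only a hydroxy does so.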